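Amide nitrogen swap, compound 2 to compound 3

The source may report more compounds than this note shows. Statements on the series, on what has been measured and on what is new or still open speak of the compounds shown alone.

Two amides of one shared core have been run in a functional assay on HeLa cells (Homo sapiens) for cytotoxicity, read by MTT assay, with a stated time of 24 h; a higher number here means a weaker inhibitor, a lower number a stronger inhibitor. Compound 1 `C=CC1=C(C(=O)Nc2ccccc2)C(c2ccc(OC)cc2)OC1` carries phenyl on the amide nitrogen. In this assay compound 1 gives > 100000 nM, which is a limit of the assay and not a number. Compound 2 `C=CC1=C(C(=O)NCCCCC)C(c2ccc(OC)cc2)OC1` carries pentyl on that nitrogen instead. In this assay compound 2 gives > 100000 nM, again a limit of the assay rather than a number. The step that the two limits leave unreadable from compound 1 to compound 2 therefore cannot be read in size or direction, since (the limit of > 100000 nM in this assay, at which 2 of the 2 values shown sit). Compound 2 thus stands only at a limit, and no ordering against compound 1 is possible.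

Compound 3 `C=CC1=C(C(=O)Nc2ccccc2OC)C(c2ccc(OC)cc2)OC1` has not been measured in this assay. It differs from compound 2 by 2-methoxyphenyl in place of pentyl on an amide-type nitrogen. Among the compounds with values here, only the step from compound 1 to compound 2 concerns the same position, and it is unreadable, so no measured step supplies a size for the change. With both neighbours at the limit, compound 3 is expected to stay at or near the limit, with an expected step that the limit leaves unreadable from compound 2 to compound 3 that is not resolvable. The estimate for compound 3 is 150000 nM, with an expected range from 50000 nM to 500000 nM, most likely reported again as a limit.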

Compound 3, half-maximal inhibitory concentration: > 100000 nM
Compound 3 ended at the assay's limit (the forecaster's own chance of this, stated with the estimate: 85%); the middle value is on the limit's open side.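

Within the data shown here, compound 1, compound 2 and compound 3 all sit at the same limit of the assay, so no step among them can be read in size or direction: the limit of > 100000 nM in this assay, at which 3 of the 3 values shown sit.

The compounds shown leave open whether any group on the amide nitrogen of the shared core gives a measurable value in this assay, and how phenyl, pentyl and 2-methoxyphenyl would rank.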